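A few compounds are considered here, and "the series" means these few. Any claim that something is new, unique, unknown or untested is made for them only; others in the source may bear on it.

In a functional assay on HL-60 cells (Homo sapiens) for inhibition, read by CCK-8 assay, with a stated time of 48 h, tested at 20 uM (a higher number here means more inhibition of growth at the concentration tested, a lower number less inhibition of growth), compound 1 (`COc1ccc(Cc2nnc(NC(=O)/C(C#N)=C/c3ccccc3OS(=O)(=O)c3ccc(F)cc3)s2)cc1`) gives 25% of growth inhibition, while compound 2 (`Cc1ccc(S(=O)(=O)Oc2ccccc2/C=C(\C#N)C(=O)Nc2nnc(Cc3ccc(F)cc3)s2)cc1`) is recorded as "not active" (no number reported) with no number attached. Compound 3 (`N#C/C(=C\c1ccccc1OS(=O)(=O)c1ccc([N+](=O)[O-])cc1)C(=O)Nc1nnc(Cc2ccc(F)cc2)s1`) stands at 18% and so lies within the scatter of compound 1, which means the two numbers cannot be ranked. Compound 4 (`N#C/C(=C\c1ccccc1OS(=O)(=O)c1ccc(F)cc1)C(=O)Nc1nnc(Cc2ccc(F)cc2)s1`) differs from compound 3 in one place, with fluoro in place of nitro on an aromatic carbon, so that 4-nitrophenyl becomes 4-fluorophenyl. Among the measured compounds shown here, no measured pair isolates this exchange, and the data offer no direct step to read from. The nearest guide is compound 1, which carries the same (4-fluorophenyl)sulfonyl group and gives 25% in a range that does not separate it from compound 3. Compound 2, recorded as "not active" (no number reported) in this series, is a reminder that a reading without a number remains possible for compound 4. No change beyond the scatter is expected, in either direction, and the estimated move is a number 2 percentage points higher from compound 3 to compound 4 (within the scatter) in size. The estimated value for compound 4 is 20% (expected range 6% to 38%).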

Compound 4, percent growth inhibition at one concentration: 13%
The estimate for compound 4 lay 7 percentage points above the measured number; measured number inside the range.
By their numbers in this assay, from the lowest: compounds 4, 3 and 1 (each within the scatter of the next, the first and the last beyond it).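

In this assay, fluoro in place of nitro on the aromatic carbon of the sulfonyl group gives a number 5 percentage points lower from compound 3 to compound 4 (within the scatter), so this exchange at this position produces no readable change, although 3 heavy atoms with 2 hydrogen-bond acceptors give way to 1 heavy atom with none. Among the compounds shown here, with the (4-fluorophenyl)sulfonyl group held constant, replacing methoxy with fluoro gives a number 12 percentage points lower from compound 1 to compound 4 (beyond the scatter), the only step here beyond the scatter and a modest one, so the one readable difference lies away from the sulfonyl group. Nothing shown here accounts for either step.

Going by these compounds, compound 2, with methyl in place of the fluoro of the (4-fluorophenyl)sulfonyl group, carries no number, so its steps cannot be read, and what an amine or a carboxylic acid at that position would do remains open. Methoxy appears only in compound 1, so it also remains open whether the step between methoxy and fluoro would hold with a nitro or methyl on the sulfonyl side, or how a longer chain such as ethoxy would compare.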